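The source may hold more compounds than are shown below. What is called first, only, known or untested is meant among the compounds shown, and "the series" means these compounds.

Compound 1 `CCOc1cccc2cc(-c3ccccc3)c(=O)oc12` belongs to a small set of compounds sharing one core, tested in an assay on CHO cells for displacement of a labelled ligand from adenosine receptor A2b (Homo sapiens), read by radioligand binding; a higher number here means a weaker inhibitor, a lower number a stronger inhibitor. For compound 1 this assay gave only a limit, > 30000 nM, and not a number. Compound 2 `CCOc1cccc2cc(-c3ccc(Br)cc3)c(=O)oc12` carries bromo in place of hydrogen on an aromatic carbon, and in this assay compound 2 likewise reached only the limit > 30000 nM. Compound 3 `CCOc1cccc2cc(-c3ccc([N+](=O)[O-])cc3)c(=O)oc12` carries nitro in place of hydrogen on an aromatic carbon, and for compound 3 this assay again reported only the limit > 30000 nM. The steps a step that the two limits leave unreadable from compound 1 to compound 2, a step that the two limits leave unreadable from compound 1 to compound 3 and a step that the two limits leave unreadable from compound 2 to compound 3 therefore cannot be read, because of the limit of > 30000 nM in this assay, at which 3 of the 3 values shown sit.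

Compound 4 `CC(=O)Oc1cccc2cc(-c3ccccc3)c(=O)oc12` is not yet measured. It differs from compound 1 by acetyl in place of ethyl on an oxygen on an aromatic ring. Within the data shown here, none of the measured steps touches this oxygen, so none bears directly on the change. Among the measured compounds shown here, what the set does show is that compound 1 and its two neighbours all sit at the limit, so a move to a readable number from compound 1 to compound 4 would have no precedent here. The step from compound 1 to compound 4 is expected to be a step that the limit leaves unreadable from compound 1 to compound 4, meaning no change beyond the scatter. Compound 4 is therefore estimated at 40000 nM, within a range from 10000 nM to 150000 nM, most probably again reported only as a limit.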

Compound 4, inhibition constant: > 30000 nM
Compound 4 was reported as a limit (the forecaster's own chance of this, stated with the estimate: 80%); the middle value lies beyond the limit too.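

In this assay compound 4 also gives only a limit, just as compound 1 does, so the step from ethoxy to acetoxy cannot be read and no size can be put on it: the limit of > 30000 nM in this assay, at which 4 of the 4 values shown sit.

The compounds shown leave open whether any change to the shared core would give a readable number at all, and how large a step any of these groups makes.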